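Cytotoxicity of an Indole Sulfonyl Amide Series on MT4 Cells

The source may hold more compounds than are shown below. What is called first, only, known or untested is meant among the compounds shown, and "the series" means these compounds.

Compound 1, `Cc1cc(C)cc(S(=O)(=O)c2c(C(=O)NCc3cccc(F)c3F)[nH]c3ccc(Cl)cc23)c1`: in an ADME assay on MT4 cells (Homo sapiens) for cytotoxicity, read by MTT assay (a lower number here means that less compound is tolerated, a higher number that more compound is tolerated), compound 1 gives > 51100 nM, which is a limit of the assay and not a number.
Compound 2, `Cc1cc(C)cc(S(=O)(=O)c2c(C(=O)NC(C)C(=O)NCc3ccco3)[nH]c3ccc(Cl)cc23)c1`: in this assay compound 2 gives 24200 nM.
Compound 3, `COc1cccc(F)c1CNC(=O)c1[nH]c2ccc(Cl)cc2c1S(=O)(=O)c1cc(C)cc(C)c1`: in this assay compound 3 gives > 49900 nM, which is a limit of the assay.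

Compound 1 therefore stands only at a limit, as does compound 3; compound 2 alone gives a number. The step of an at least 2.1-fold lower number from compound 1 to compound 2 (0.32 log units; beyond the scatter) shows that exchanging the amide substituent can lower the tolerated concentration, while an at least 2.0-fold higher number from compound 2 to compound 3 (0.31 log units; beyond the scatter) runs the other way and a step that the two limits leave unreadable from compound 1 to compound 3 cannot be read between two limits, as the limit of > 51100 nM in this assay, at which 1 of the 3 values shown sits, and the limit of > 49900 nM in this assay, at which 1 of the 3 values shown sits, show.

Compound 4, `Cc1cc(C)cc(S(=O)(=O)c2c(C(=O)Nc3cc(C#N)ccn3)[nH]c3ccc(Cl)cc23)c1`, has not yet been measured. The change from compound 1 is 4-cyanopyridin-2-yl in place of 2,3-difluorobenzyl on an amide-type nitrogen. Going by the values given here, the only step with a readable size bears on the same amide-type nitrogen and was at least modest, so a drop of similar size is possible, but a value at the limit is equally likely. Compound 4 is therefore expected to give about 40000 nM, between 18000 nM and 60000 nM, which is an estimated step of an at least 1.2-fold lower number from compound 1 to compound 4 (0.10 log units; that floor lies within the scatter).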

Compound 4, half-maximal cytotoxic concentration: > 53700 nM
Compound 4 gave a limit, no number; the forecaster's own chance of this, stated with the estimate: 50%; at least 1.3-fold (0.12 log units) between middle value and limit.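

Until now the amide-type nitrogen had carried only benzyl groups and the chain of compound 2, and compound 4 extends the tolerated range to a 4-cyanopyridin-2-yl group, an aromatic ring with 1 hetero atom and a nitrile, which also reaches a limit of the assay: the limit of > 53700 nM in this assay, at which 1 of the 4 values shown sits. Exchanging the chain of compound 2 for this group gives an at least 2.2-fold higher number from compound 2 to compound 4 (0.34 log units; beyond the scatter), so among the four compounds shown, only the chain of compound 2 gives a number. The steps from compound 1 and from compound 3 to compound 4 lie between two limits and cannot be read.

On these data alone, how far compounds 1, 3 and 4 differ from one another in this assay remains open. As far as these compounds go, it is also open whether a 2-aminoethyl group or a carboxylic acid on a short chain at this nitrogen would give a number, as compound 2 does.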